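Swapping butyl for benzyl on the sulfur of compound 3

The compounds below may be only part of what the source reports. "The series", "measured", "known", "first", "only" and "open" are said of these compounds alone.

Compound 1 `CC(C(=O)NCc1ccc(C(C)(C)C)nc1N1CCCC1)c1ccc(NS(C)(=O)=O)c(F)c1`: 1.2 nM in an assay on cells for antagonist activity at transient receptor potential cation channel subfamily V member 1 (Homo sapiens), read by FLIPR and calcium flux, with a stated time of 6 min; on this read-out lower numbers stand for stronger inhibition and higher numbers for weaker inhibition
Compound 2 `CCC1CCN(c2nc(C(C)(C)C)ccc2CNC(=O)C(C)c2ccc(NS(C)(=O)=O)c(F)c2)CC1`: 0.1 nM
Compound 3 `CCCCSc1nc(C(C)(C)C)ccc1CNC(=O)C(C)c1ccc(NS(C)(=O)=O)c(F)c1`: 3.2 nM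

Compound 3 stands highest of the three numbers in this assay: both a 2.7-fold higher number from compound 1 to compound 3 (0.43 log units; beyond the scatter) and a 32-fold higher number from compound 2 to compound 3 (1.51 log units; beyond the scatter) rise, so it is the weakest of the measured set. Compound 4 `CC(C(=O)NCc1ccc(C(C)(C)C)nc1SCc1ccccc1)c1ccc(NS(C)(=O)=O)c(F)c1` differs from compound 3 by phenyl in place of propyl on a saturated chain carbon bound to a sulfur. Among the measured compounds shown here, no measured step alters the chain on the sulfur, so the bearing of the known steps is indirect. For the measured compounds named here, the only step that enlarges a substituent on the core, a 12-fold lower number from compound 1 to compound 2 (1.08 log units; beyond the scatter), fell strongly, which hints that growth at this position can be rewarded. A small lowering, a 1.6-fold lower number from compound 3 to compound 4 (0.20 log units; within the scatter), is therefore expected, though it may lie within the scatter. Compound 4 is estimated at 2 nM, between 0.5 nM and 8 nM.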

Compound 4, inhibition constant: 4 nM
Beside the measured number, compound 4's estimate is 2.0-fold (0.30 log units) below it, within the range that was stated.
By their numbers in this assay, from the lowest: compound 2; then compound 1; then compounds 3 and 4 (each within the scatter of the next).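

In this assay, a benzyl group on the sulfur reads the same as a butyl group, within the scatter (a 1.3-fold higher number from compound 3 to compound 4 (0.10 log units; within the scatter)), so adding a phenyl ring to the end of this chain gives no measurable gain. Benzylsulfanyl also leaves the number higher than the two ring amines do (a 3.3-fold higher number from compound 1 to compound 4 (0.52 log units; beyond the scatter); a 40-fold higher number from compound 2 to compound 4 (1.60 log units; beyond the scatter)), as butylsulfanyl did. Nothing here explains these results. Still open, as far as these compounds go, is whether a longer chain on the sulfur, such as hexyl, would shift the number. An oxygen in place of the sulfur, as in a benzyloxy group, is also untested among these compounds.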